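This account rests on a few compounds, and the source may have more. Where it says the series, first, only, none or still open, it means among the compounds named here.

Compound 2 `C=C1C[C@]23C[C@@]1(O)CC[C@H]2c1ccc(O)c(C)c1[C@@H]3Cn1cc(-c2ccc(C(F)(F)F)cc2)nn1` serves as the reference point of this small set. In a functional assay on HL-60 cells (Homo sapiens) for cytotoxicity, read by MTT assay, with a stated time of 4 days (on this read-out lower numbers stand for stronger inhibition and higher numbers for weaker inhibition), compound 2 gives 8950 nM. Compound 1 `C=C1C[C@]23C[C@@]1(O)CC[C@H]2c1ccc(O)c(C)c1[C@@H]3Cn1cc(-c2ccccn2)nn1` differs from it by pyridin-2-yl in place of 4-(trifluoromethyl)phenyl on an aromatic carbon. In this assay compound 1 gives > 20000 nM, which is a limit of the assay and not a number. That change produced an at least 2.2-fold higher number from compound 2 to compound 1 (0.34 log units; beyond the scatter). Compound 3 `C=C1C[C@]23C[C@@]1(O)CC[C@H]2c1ccc(OS(=O)(=O)c2ccc(C)cc2)c(C)c1[C@@H]3Cn1cc(-c2ccc(C(F)(F)F)cc2)nn1` differs from compound 2 by (4-methylphenyl)sulfonyl in place of hydrogen on an oxygen on an aromatic ring. In this assay compound 3 gives > 20000 nM, again a limit of the assay rather than a number. The corresponding step is an at least 2.2-fold higher number from compound 2 to compound 3 (0.34 log units; beyond the scatter).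

Compound 4 `C=C1C[C@]23C[C@@]1(O)CC[C@H]2c1ccc(OS(=O)(=O)c2ccc(C)cc2)c(C)c1[C@@H]3Cn1cc(-c2ccccn2)nn1` has not yet been measured. It differs from compound 3 by pyridin-2-yl in place of 4-(trifluoromethyl)phenyl on an aromatic carbon. This is the same change as that from compound 2 to compound 1, and the surroundings of the place are the same word for word. On the earlier occasion the change made an at least 2.2-fold higher number from compound 2 to compound 1 (0.34 log units; beyond the scatter). Here the starting point is different, because compound 3 already sits at the limit of > 20000 nM in this assay, at which 2 of the 3 values shown sit. Any weakening the change might bring cannot be seen once that limit is reached, and nothing among the measured compounds suggests that the change would strengthen inhibition. Compound 4 is therefore expected to stay at the limit, with an expected step that the limit leaves unreadable from compound 3 to compound 4. Compound 4 is estimated at 40000 nM, with a range from 20000 nM to 120000 nM, and a report of only a limit is the most likely outcome.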

Compound 4, half-maximal inhibitory concentration: > 20000 nM
Compound 4 ended at the assay's limit (the forecaster's own chance of this, stated with the estimate: 90%); the middle value does not contradict the limit.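

Compound 4 sits at a limit of the assay, as do compound 1 and compound 3, so neither the step from compound 3 to compound 4 nor the step from compound 1 to compound 4 can be read: the limit of > 20000 nM in this assay, at which 3 of the 4 values shown sit. The compounds shown leave open what true values compound 1, compound 3 and compound 4 have, and so whether the two changes add together in compound 4.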